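This account rests on a few compounds, and the source may have more. Where it says the series, first, only, none or still open, it means among the compounds named here.

Compound 2 `N#Cc1c(Nc2cccc([N+](=O)[O-])c2)nc(SCc2cn(Cc3ccccc3Cl)nn2)nc1-c1ccccc1` in a functional assay on ECa-109 cells (Homo sapiens) for inhibition, read by MTT assay, with a stated time of 72 h (on this read-out lower numbers stand for stronger inhibition and higher numbers for weaker inhibition), gives only a limit, > 64000 nM, which is the limit of > 64000 nM in this assay, at which 2 of the 3 values shown sit. Compound 1 `N#Cc1c(Nc2cccc(C(F)(F)F)c2)nc(SCc2cn(Cc3ccccc3Cl)nn2)nc1-c1ccccc1` gives 32000 nM in this assay. Among the measured compounds shown here, the step of an at least 2.0-fold higher number from compound 1 to compound 2 (0.30 log units; that floor lies within the scatter) is the one measured change that bears on the present question, as it exchanges a single group on the same nitrogen. Compound 3 `Cc1ccccc1Nc1nc(SCc2cn(Cc3ccc(Cl)cc3)nn2)nc(-c2ccccc2)c1C#N`, carrying a 2-methylphenyl group as well as a change elsewhere, also gives only a limit, > 64000 nM. Compound 4 `Cc1ccc(Nc2nc(SCc3cn(Cc4ccccc4Cl)nn3)nc(-c3ccccc3)c2C#N)cc1` is not yet measured; it differs from compound 2 by 4-methylphenyl in place of 3-nitrophenyl on a nitrogen on an aromatic ring. Removing the nitro group in compound 1 gave a reported number rather than a limit, so the step of an at least 1.6-fold lower number from compound 2 to compound 4 (0.20 log units; that floor lies within the scatter) is expected to be modest and to bring the value back toward a measurable number. Compound 4 is therefore estimated at 40000 nM, with a range from 15000 nM to 128000 nM.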

Compound 4, half-maximal inhibitory concentration: > 64000 nM
Compound 4: no number, only a limit; the forecaster's own chance of this, stated with the estimate: 55%; at least 1.6-fold (0.20 log units) between middle value and limit.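

Compound 4 gives only a limit, the same limit as compound 2: the limit of > 64000 nM in this assay, at which 3 of the 4 values shown sit. Among the compounds shown here, the step between these two compounds cannot be read, but it shows that 4-methylphenyl on this nitrogen, like 3-nitrophenyl, gives no measurable number, leaving compound 1 with 3-(trifluoromethyl)phenyl as the only compound here that has one. The comparison that can be read is an at least 2.0-fold higher number from compound 1 to compound 4 (0.30 log units; that floor lies within the scatter), so even this difference is not firm.

On these data alone, it remains open whether an aminophenyl group or a longer alkyl chain on this nitrogen would give a measurable number in this assay.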